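Sulfamoyl for formyl on the ring nitrogen of compound 2

A few compounds are considered here, and "the series" means these few. Any claim that something is new, unique, unknown or untested is made for them only; others in the source may bear on it.

Of the compounds shown here, two have numbers so far in a functional assay on CHO cells for antagonist activity at C-X-C chemokine receptor type 3 (Homo sapiens), read by GTPgammaS binding, with a stated time of 30 min; a higher number here means a weaker inhibitor, a lower number a stronger inhibitor. Compound 1 `O=C1CCC(c2ccccn2)(C2CCN(Cc3ccc(Br)cc3)CC2)C(=O)N1` gives 500 nM in this assay. Compound 2 `O=CN1CCCC(c2ccccc2)(C2CCN(Cc3ccc(Br)cc3)CC2)C1` gives 150 nM in this assay, the lower of the two numbers; the gap to compound 1 lies beyond the scatter, but compound 1 and compound 2 differ in more than one place, so no single change can be read from that pair.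

Compound 3 `NS(=O)(=O)N1CCCC(c2ccccc2)(C2CCN(Cc3ccc(Br)cc3)CC2)C1` is not yet measured. It differs from compound 2 by sulfamoyl in place of formyl on an amine nitrogen in a ring. Going by the values given here, no measured pair shows what such a change does, so there is no step to lean on. The expectation is therefore held close to compound 2, with a wide spread to either side and no direction favoured beyond the scatter. Compound 3 is expected to give about 200 nM in this assay, with a range from 50 nM to 800 nM, which would mean an estimated step of a 1.3-fold higher number from compound 2 to compound 3 (0.12 log units; within the scatter).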

Compound 3, half-maximal inhibitory concentration: 210 nM
Compound 3: the middle estimate sits 1.1-fold (0.02 log units) below what was measured; the measured number falls inside the stated range.
By their numbers in this assay, from the lowest: compounds 2 and 3 (each within the scatter of the next); then compound 1.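

In this assay, going by these compounds alone, sulfamoyl in place of formyl on the amine nitrogen in the ring comes with a 1.4-fold higher number from compound 2 to compound 3 (0.15 log units; within the scatter), the first step that can be read at a single place. At this position, sulfamoyl, with 4 heavy atoms and 1 hydrogen-bond donor, replaces formyl, with 2 heavy atoms and 0 hydrogen-bond donors, and the two numbers still cannot be told apart, so this change on the ring nitrogen shows no measurable effect on the read-out. Nothing available bears on why the two numbers stay this close.

The compounds shown leave open whether that nitrogen is as undemanding for other groups, such as methylsulfonyl, acetyl, a longer acyl chain or a plain amine hydrogen, since one exchange cannot separate a general lack of effect from a match between these two groups. Compound 1 differs from compound 2 and compound 3 in more than one place, so the gap between its number and theirs cannot yet be assigned to any single part of the structure.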